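Carboxylic acid on the biaryl of a bicyclic lactam series

A few compounds are considered here, and "the series" means these few. Any claim that something is new, unique, unknown or untested is made for them only; others in the source may bear on it.

Measured so far:
compound 1, `O=C1c2ccc(OCc3cccc(-c4ccc(Cl)cc4F)c3)cc2CN1C1CCCC1`: > 5000 nM
compound 2, `O=C(O)c1cc(-c2cccc(COc3ccc4c(=O)n(C5CC5)sc4c3)c2)ccc1Cl`: 130 nM

In an assay on HEK293 cells for positive allosteric modulation of metabotropic glutamate receptor 2 (Rattus norvegicus), read by thallium flux (a higher number here means that more compound is needed for the effect, a lower number that less compound is needed), compound 1 gives only > 5000 nM, which is a limit of the assay and not a number, so compound 1 stands at the edge of the range with no figure of its own. Compound 2, built on a different core, gives 130 nM in this assay. For the measured compounds named here, no step between two measured compounds is available here, since the two differ in more than one place.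

Compound 3, `O=C(O)c1ccc(-c2cccc(COc3ccc4c(c3)CN(C3CCCC3)C4=O)c2)c(Cl)c1`, keeps the core of compound 1 and changes the biaryl: 4-carboxy-2-chlorophenyl in place of 4-chloro-2-fluorophenyl on an aromatic carbon. The change brings in the same carboxy-chlorophenyl group that compound 2 carries, while compound 1 sits at the limit because of the limit of > 5000 nM in this assay, at which 1 of the 2 values shown sits.

Compound 3 is therefore expected to reach a measurable value in this assay, with the step of an at least 12-fold lower number from compound 1 to compound 3 (1.09 log units; beyond the scatter) judged well beyond the scatter. The estimate for compound 3 is 400 nM, within 80 nM to 3000 nM.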

Compound 3, half-maximal effective concentration: 110 nM
Beside the measured number, compound 3's estimate is 3.6-fold (0.56 log units) above it; low and high end bracket the measured number.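

In this assay, 4-carboxy-2-chlorophenyl in place of 4-chloro-2-fluorophenyl on an aromatic carbon, meta to a large group, gives an at least 45-fold lower number from compound 1 to compound 3 (1.65 log units; beyond the scatter). Compound 1 gives > 5000 nM, which is a limit of the assay and not a number, so the step is only a bound on the true size of the change: the limit of > 5000 nM in this assay, at which 1 of the 3 values shown sits. On the core of compound 1, this one position therefore yields a measurable read-out, and compound 3 gives 110 nM.

For the compounds shown here, the single step swaps the carboxylic acid and the two halogens together, so the share of each in the change stays open. Also open, on these data alone, is whether a methyl ester, a primary amide or a tetrazole at the same place would give a measurable value.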